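Nitrophenyl for Chlorophenyl in a Weakly Cytotoxic Series

The compounds below may be only part of what the source reports. "The series", "measured", "known", "first", "only" and "open" are said of these compounds alone.

Compound 1, `O=C(CN1CCN(c2ccccc2)CC1)N1CCN(c2nnc(-c3ccccc3)c(-c3ccccc3)n2)CC1`: > 963000 nM
Compound 2, `COc1ccc(-c2nnc(N3CCN(C(=O)CN4CCN(c5ccc([N+](=O)[O-])cc5)CC4)CC3)nc2-c2ccc(OC)cc2)cc1`: > 801000 nM
Compound 3, `O=C(CN1CCN(c2ccccc2Cl)CC1)N1CCN(c2nnc(-c3ccc(Cl)cc3)c(-c3ccc(Cl)cc3)n2)CC1`: 396000 nM

In a functional assay on MCF7 cells (Homo sapiens) for cytotoxicity, read by MTT assay, with a stated time of 24 h (a lower number here means a stronger inhibitor, a higher number a weaker inhibitor), compound 3 gives 396000 nM. Among the measured compounds shown here, this is the only number in the set. For compound 1 the entry is a limit of the assay, (the limit of > 963000 nM in this assay, at which 1 of the 3 values shown sits). For compound 2 the entry is also a limit of the assay, (the limit of > 801000 nM in this assay, at which 1 of the 3 values shown sits). For the measured compounds named here, compound 3 therefore stands alone as the one compound with a measured value, and no step between measured compounds can be sized.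

Compound 4, `O=C(CN1CCN(c2ccc([N+](=O)[O-])cc2)CC1)N1CCN(c2nnc(-c3ccc(Cl)cc3)c(-c3ccc(Cl)cc3)n2)CC1`, differs from compound 3 in one place: 4-nitrophenyl in place of 2-chlorophenyl on an amine nitrogen in a ring. Going by the values given here, compound 2 carries the same 4-nitrophenyl and sits at a limit, while compound 1, with a plain phenyl, also sits at a limit, so the numbers give no measured step to lean on.

With nothing measured beyond a single number, compound 4 is expected to land near compound 3, with the step from compound 3 to compound 4 estimated as a 1.5-fold higher number from compound 3 to compound 4 (0.18 log units; within the scatter) in this assay. Compound 4 is estimated at 600000 nM, in a range from 250000 nM to 1000000 nM, with a real chance that only a limit is reported.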

Compound 4, half-maximal inhibitory concentration: > 789000 nM
Compound 4 gave a limit, no number (the forecaster's own chance of this, stated with the estimate: 45%); at least 1.3-fold (0.11 log units) between middle value and limit.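

In this assay, among the compounds shown here, the change to 4-nitrophenyl in place of 2-chlorophenyl on an amine nitrogen in a ring gives the first step in this set that can be read, with the rest of the structure held constant: an at least 1.9-fold higher number from compound 3 to compound 4 (0.29 log units; that floor lies within the scatter). This step is only a floor, and as printed it does not separate the two compounds beyond the scatter, so this position has not yet been shown to respond to the change, though a larger real step remains possible. For compound 4 the entry is a limit of the assay and not a number: the limit of > 789000 nM in this assay, at which 1 of the 4 values shown sits.

The steps that would involve compound 1 or compound 2 cannot be read, so the compounds shown say nothing on how the same change behaves on another core or whether a plain phenyl at this place would differ from either group. Also open, from the compounds shown here alone, is how this position would take a basic or acidic substituent on the aromatic ring, such as a dimethylamino group or a carboxylic acid, and whether any such group would bring a measured value well below those seen here.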